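Ester exchange on a quinolinone core and expected cytotoxicity

The compounds below may be only part of what the source reports. "The series", "measured", "known", "first", "only" and "open" are said of these compounds alone.

Of the compounds shown here, two sharing one core have been measured in an ADME assay on HepG2 2.2.15 cells (Homo sapiens) for cytotoxicity; on this read-out higher numbers stand for lower toxicity in this test and lower numbers for higher toxicity in this test. Compound 1, `Cn1c(=O)c(CCO)c(-c2ccccc2Cl)c2cc(Cl)ccc21`, gives 34000 nM. Compound 2, `COCC(=O)OCCc1c(-c2ccccc2Cl)c2cc(Cl)ccc2[nH]c1=O`, gives 74000 nM. Of these two numbers compound 2 holds the higher one. The gap between compound 2 and compound 1 is beyond the usual scatter of repeated measurements, and compound 2 counts as the less toxic of the pair in this assay.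

Compound 3, `COc1ccccc1/C=C/C(=O)OCCc1c(-c2ccccc2Cl)c2cc(Cl)ccc2[nH]c1=O`, has not yet been measured. It differs from compound 2 in the ester part only: 2-(2-methoxyphenyl)ethenyl in place of methoxymethyl on a carbonyl carbon. The carbonyl carbon and the oxygen next to it stay as they are; what hangs from the carbonyl carbon grows from a short chain into a chain carrying a six-membered aromatic ring.

Among the measured compounds shown here, no measured pair here shows what such an exchange does in this assay, so the expectation rests on compound 2 alone. A modest fall in the number, possibly no larger than the scatter, is expected, giving a 1.9-fold lower number from compound 2 to compound 3 (0.27 log units; within the scatter). For compound 3 the value is estimated at 40000 nM, with a range from 15000 nM to 100000 nM.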

Compound 3, half-maximal cytotoxic concentration: 770000 nM
Estimate against measurement, compound 3: 19-fold (1.28 log units) below; the whole stated range lies below it.
By their numbers in this assay, from the lowest: compound 1; then compound 2; then compound 3.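

Exchanging methoxymethyl for 2-(2-methoxyphenyl)ethenyl on this carbonyl carbon gives a 10-fold higher number from compound 2 to compound 3 (1.02 log units; beyond the scatter) in this assay, so the group at this position can move the read-out well beyond the usual scatter, even with the rest of the molecule unchanged. The direction is toward lower toxicity in this test, which means that here a much larger group, bringing a six-membered aromatic ring and a double bond outside that ring, comes with no rise in toxicity. Nothing available here explains why this exchange has so large an effect.

The compounds shown leave open which part of the new group goes with the step: the aromatic ring, the double bond or the methoxy group on the ring. A 2-phenylethyl group, a plain phenyl group, or a chain ending in an amine or a carboxylic acid on the same carbonyl carbon would help to separate these parts and show how far the trend extends.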